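The compounds below may be only part of what the source reports. "The series", "measured", "known", "first", "only" and "open" are said of these compounds alone.

Compound 1 `CCC(C)n1cnc2c(NCc3ccc(C(=O)Nc4ccccc4N)cc3)nc(Cl)nc21` gives 720 nM in a functional assay on HCT-116 cells (Homo sapiens) for antiproliferative activity, read by CCK-8 assay, with a stated time of 72 h; a lower number here means a stronger inhibitor, a higher number a weaker inhibitor. Within the data shown here, compound 2 `Nc1ccccc1NC(=O)c1ccc(Cn2cnc3c(Nc4ccc(-c5ccccn5)cc4)nc(Cl)nc32)cc1` gives 1250 nM, and these two values lie within the usual scatter of each other, so compound 1 stands level with the only other compound measured so far. Compound 3 `Nc1ccccc1NC(=O)c1ccc(CNc2nc(Cl)nc3c2ncn3C2CCCC2)cc1` has not yet been measured. It keeps the core of compound 1 but has cyclopentyl in place of sec-butyl on an aromatic nitrogen. Among the measured compounds shown here, no two measured compounds differ in one place only, so the data hold no direct precedent for this change. In this assay, no step beyond the scatter is expected in either direction, and this expectation rests on compound 1 at 720 nM. The estimated step is small, a 1.1-fold lower number from compound 1 to compound 3 (0.04 log units; within the scatter). For compound 3 the estimated value is 650 nM, with an expected range of 250 nM to 1700 nM.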

Compound 3, half-maximal inhibitory concentration: 850 nM
Beside the measured number, compound 3's estimate is 1.3-fold (0.12 log units) below it; low and high end bracket the measured number.
By their numbers in this assay, from the lowest: compounds 1, 3 and 2 (each within the scatter of the next).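

In this assay, among these compounds, putting cyclopentyl in place of sec-butyl on the aromatic nitrogen gives a 1.2-fold higher number from compound 1 to compound 3 (0.07 log units; within the scatter) and so provides the first direct comparison at this position. At this place on the shared core, a five-membered non-aromatic ring of carbon only serves as well as the open sec-butyl group, and the one added carbon and the ring closure leave the read-out unmoved beyond the scatter. Nothing available gives a reason for this result.

Both groups contain carbon only, so the compounds shown leave open whether an amine, a hydroxyl or a carboxylic acid on this nitrogen would move the number beyond the scatter. They also leave open whether a group as small as methyl would do the same.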